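A few compounds are considered here, and "the series" means these few. Any claim that something is new, unique, unknown or untested is made for them only; others in the source may bear on it.

Compound 3 `OC(CCCCCCc1ccccc1)c1ncc(C(F)(F)F)o1` gives 2300 nM in an assay (Rattus norvegicus) for inhibition of Fatty-acid amide hydrolase 1 (Homo sapiens) (on this read-out higher numbers stand for weaker inhibition and lower numbers for stronger inhibition), the highest number among the three measured compounds. Compound 1 `NC(=O)c1ccc(-c2cnc(C(=O)CCCCCCc3ccccc3)o2)cc1` gives 10 nM in this assay, and compound 2 `O=C(CCCCCCc1ccccc1)c1ncc(-c2cncnc2)o1` gives 22 nM; both stand far below compound 3. Compound 4 `O=C(O)c1cccc(-c2cnc(C(O)CCCCCCc3ccccc3)o2)n1` differs from compound 3 in one place: 6-carboxypyridin-2-yl in place of trifluoromethyl on an aromatic carbon. Going by the values given here, no measured step removes a trifluoromethyl or introduces a carboxypyridinyl group. Among the compounds with values here, the only step among the measured compounds, a 2.2-fold higher number from compound 1 to compound 2 (0.34 log units; beyond the scatter), exchanges one aromatic group for another on the shared core and is modest; it shows that two different aromatic groups at that place go with similar numbers, but compounds 1 and 2 carry a carbonyl where compounds 3 and 4 carry a hydroxyl, so that step bears only loosely on the change at hand. Since compound 1, which bears an aromatic group at that place, gives the low number 10 nM and compound 2, which bears an aromatic group there too, gives the low number 22 nM, a lower number is expected for compound 4, as a 5.8-fold lower number from compound 3 to compound 4 (0.76 log units; beyond the scatter), though with wide uncertainty. Compound 4 is therefore estimated at 400 nM, within a range from 60 nM to 3000 nM.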

Compound 4, inhibition constant: > 10000 nM
Compound 4 ended at the assay's limit; the forecaster's own chance of this, stated with the estimate: 5%; middle value at least 25-fold (1.39 log units) from the limit.
By their numbers in this assay, from the lowest: compound 1; then compound 2; then compound 3. At a limit, above all of these: compound 4.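

On the hydroxyl compounds, 6-carboxypyridin-2-yl in place of trifluoromethyl on this aromatic carbon, next to the ring oxygen, gives in this assay an at least 4.3-fold higher number from compound 3 to compound 4 (0.63 log units; beyond the scatter), so an aromatic group at this place does not by itself go with a low number. Compound 4 stands at a limit, which is not a number, so the step has a lower bound only: the limit of > 10000 nM in this assay, at which 1 of the 4 values shown sits. The low numbers seen with 4-carbamoylphenyl and pyrimidin-5-yl on the carbonyl compounds therefore do not extend to this group on a hydroxyl compound.

On these data alone, it remains open whether a plain pyridin-2-yl, or a methyl ester in place of the carboxylic acid, would also stand at the limit on the hydroxyl compound. Also open, as far as these compounds go, is how a carbonyl in place of the hydroxyl would read with 6-carboxypyridin-2-yl at this place.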